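The compounds below may be only part of what the source reports. "The series", "measured", "known", "first", "only" and "open" are said of these compounds alone.

In an ADME assay on a cell-free system (plasma, Mus musculus) for metabolic stability, read by LC-MS, tested at 2 uM (on this read-out lower numbers stand for a shorter-lived compound and higher numbers for a longer-lived compound), compound 1 (`CN1CCC(c2ccc3c(c2)oc(=O)n3C(=O)NCCCCc2ccc(F)cc2)CC1`) gives 0.333 h and so stands level with compound 2 (`CN1CCN(c2ccc3c(c2)oc(=O)n3C(=O)NCCCCc2ccccc2)C(=O)C1`) at 0.333 h and compound 3 (`CN1CCN(c2ccc3c(c2)oc(=O)n3C(=O)NCCCCc2ccccc2)CC1=O`) at 0.333 h on the numbers available. Compound 4 (`CN1CCC(c2ccc3c(c2)oc(=O)n3C(=O)NCCOCc2ccccc2)CC1`) keeps the core of compound 1 and alters the chain (benzyloxy in place of 2-(4-fluorophenyl)ethyl on a saturated chain carbon, two bonds along the chain from an amide-type nitrogen) with benzyloxy in place of 2-(4-fluorophenyl)ethyl on a saturated chain carbon, two bonds along the chain from an amide-type nitrogen. Going by the values given here, the only measured step shows no change at the digits printed from compound 2 to compound 3 (within the scatter) and concerns 4-methyl-3-oxopiperazin-1-yl in place of 4-methyl-2-oxopiperazin-1-yl on an aromatic carbon, not the chain. Among the compounds with values here, no measured step isolates a chain change, so the guidance is indirect. The three equal values give no sign of a shift, so no step beyond the scatter is expected in this assay and no direction is favoured. The expected step is a 1.1-fold higher number from compound 1 to compound 4 (0.02 log units; within the scatter) in this estimate. For compound 4 the expected half-life is 0.35 h with an estimated range from 0.2 h to 0.7 h as a working figure.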

Compound 4, half-life: 0.667 h
Compound 4: the middle estimate sits 1.9-fold (0.28 log units) below what was measured; the range from low to high includes it.
By their numbers in this assay, from the lowest: compounds 1, 2, 3 and 4 (each within the scatter of the next).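

In this assay, going by these compounds alone, the one step at the chain reads a 2.0-fold higher number from compound 1 to compound 4 (0.30 log units; within the scatter) and so places benzyloxy in place of 2-(4-fluorophenyl)ethyl within the scatter on the core of compound 1. The exchange removes the fluorine and adds a hydrogen-bond acceptor at once, and these compounds cannot separate the two. Nothing measured here accounts for the step.

As far as these compounds go, whether the oxygen of benzyloxy or the fluorine counts on its own stays open, as does how an amine, a carboxylic acid or a longer chain at this place would read in this assay on the same core. Also open, from the compounds shown here alone, is whether the same exchange reads alike with 4-methyl-2-oxopiperazin-1-yl or 4-methyl-3-oxopiperazin-1-yl on the aromatic carbon.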